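Bromo substitution on two cores in the cytotoxicity series

This account rests on a few compounds, and the source may have more. Where it says the series, first, only, none or still open, it means among the compounds named here.

Compound 2 `O=C1NC[C@@H](c2c[nH]c3ccccc23)N=C1c1c[nH]c2ccccc12` and compound 1 `O=C1NC[C@@H](c2c[nH]c3cc(Br)ccc23)N=C1c1c[nH]c2ccccc12` share one core. In an ADME assay on SK-OV-3 cells (Homo sapiens) for cytotoxicity (a lower number here means that less compound is needed, a higher number that more compound is needed for the effect), compound 2 gives 12.6 ug/mL, and compound 1 gives 8.5 ug/mL. The change between them is bromo in place of hydrogen on an aromatic carbon, and it produced a 1.5-fold lower number from compound 2 to compound 1 (0.17 log units; within the scatter).

Compound 3 `O=C1NC[C@@H](c2c[nH]c3ccccc23)N[C@H]1c1c[nH]c2ccccc12` rests on a second core. The difference between the two cores is not broken down here. In this assay compound 3 gives 9.64 ug/mL, a value that sits within the scatter of both compound 1 and compound 2.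

Compound 4 `O=C1NC[C@@H](c2c[nH]c3ccccc23)N[C@H]1c1c[nH]c2cc(Br)ccc12` is not yet measured in this assay. It carries the change (bromo in place of hydrogen on an aromatic carbon), placed on the core of compound 3. The place is described in the same words for both pairs, so this is the same change, now seen a second time in the set.

For the measured compounds named here, the only guide is the single earlier step, a 1.5-fold lower number from compound 2 to compound 1 (0.17 log units; within the scatter), which was itself within the scatter. On that basis the expected step is a 1.5-fold lower number from compound 3 to compound 4 (0.17 log units; within the scatter), small and of the same direction. For compound 4 the estimate in this assay is 6.5 ug/mL, with an expected range from 3.5 ug/mL to 12 ug/mL.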

Compound 4, concentration for half-maximal effect: 5.67 ug/mL
Estimate against measurement, compound 4: 1.1-fold (0.06 log units) above; the measured number falls inside the stated range.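

In this assay, bromo in place of hydrogen on an aromatic carbon gives a 1.7-fold lower number from compound 3 to compound 4 (0.23 log units; within the scatter), on the core of compound 3. Set beside the earlier step on the core of compound 1, the new step does not stand apart from it: the same change on two cores in this assay, a 1.5-fold lower number (0.17 log units; within the scatter) from compound 2 to compound 1 and a 1.7-fold lower number (0.23 log units; within the scatter) from compound 3 to compound 4, 1.1-fold (0.06 log units) apart, within the scatter of two such steps. This shows that the change carried from one core to the other without a difference beyond the scatter, but each step also lies within the scatter on its own, so it does not show that bromo truly shifts the number on either core, and two pairs in a single assay set no rule for the series.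

Only bromo enters in the compounds shown, so it remains open whether chloro, a methoxy group, an amine or a carboxylic acid on the same aromatic carbon would give a step that can be told from the scatter. Also open, on these data alone, is whether any such step would carry between these two cores as bromo does.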